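A urea tail with added chloro for compound 2

The source may report more compounds than this note shows. Statements on the series, on what has been measured and on what is new or still open speak of the compounds shown alone.

Three compounds share one core and have been run in a functional assay on OVCAR-8 cells (Homo sapiens) for inhibition, read by sulforhodamine B assay, with a stated time of 48 h; on this read-out higher numbers stand for weaker inhibition of growth and lower numbers for stronger inhibition of growth. Compound 1 `O=C(Nc1cccc(-n2cc(-c3ccncc3)c(-c3ccc(Cl)c(O)c3)n2)c1)Nc1cccc(C(F)(F)F)c1` gives 1570 nM. Compound 2 `COc1cc(-c2nn(-c3cccc(NC(=O)c4cccc(C(F)(F)F)c4)c3)cc2-c2ccncc2)ccc1Cl` gives 2000 nM, the highest of the three numbers; its gap to compound 1 is within the scatter, while compound 3 `O=C(Nc1cccc(-n2cc(-c3ccncc3)c(-c3ccc(Cl)c(O)c3)n2)c1)Nc1cc(C(F)(F)F)cc(C(F)(F)F)c1` gives 563 nM, a clear distance below it. For the measured compounds named here, the only single-point step among them is a 2.8-fold lower number from compound 1 to compound 3 (0.45 log units; beyond the scatter), so adding a trifluoromethyl group to the outer ring helped by a modest margin.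

Compound 4 `COc1cc(-c2nn(-c3cccc(NC(=O)Nc4ccc(Cl)c(C(F)(F)F)c4)c3)cc2-c2ccncc2)ccc1Cl` is not yet measured. Against compound 2 the change is (4-chloro-3-(trifluoromethyl)phenyl)amino in place of 3-(trifluoromethyl)phenyl on a carbonyl carbon: the amide of compound 2 becomes a urea, and the outer ring carries a chloro group next to the trifluoromethyl already present. Going by the values given here, no measured pair isolates this exact change. What is known is that compounds 1 and 3, both ureas, sit at or below compound 2, and that enlarging the outer ring's substitution lowered the number from compound 1 to compound 3.

On that basis compound 4 is expected to come in somewhat lower than compound 2, a step of a 2.9-fold lower number from compound 2 to compound 4 (0.46 log units; beyond the scatter) in this assay. The estimate for compound 4 is 700 nM, within a range from 250 nM to 2500 nM.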

Compound 4, concentration for 50% growth inhibition: 1050 nM
Compound 4: the middle estimate sits 1.5-fold (0.18 log units) below what was measured, and the stated range covers the measured number.
By their numbers in this assay, from the lowest: compounds 3, 4, 1 and 2 (each within the scatter of the next, the first and the last beyond it).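

In this assay, for the compounds shown here, putting (4-chloro-3-(trifluoromethyl)phenyl)amino in place of 3-(trifluoromethyl)phenyl on the carbonyl carbon gives a 1.9-fold lower number from compound 2 to compound 4 (0.28 log units; within the scatter), so this is the first direct look at this position, and the larger group leaves the read-out inside the normal noise of the assay. The swap is also a double change: it turns the amide of compound 2 into the urea of compound 4, adding a nitrogen with one hydrogen-bond donor, and it adds a chlorine to the outer ring, so any small contribution from either part, or two contributions that offset each other, would look the same in this single step. Nothing available here explains why the step is this size.

The compounds shown do not separate the urea nitrogen from the chlorine, since none of them carries just one of these two changes on the core of compound 2. Also open, from the compounds shown here alone, is how this position would respond to a different group on the outer ring, such as a nitrile, a methyl or a carboxylic acid, in place of the chlorine.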